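The source may report more compounds than this note shows. Statements on the series, on what has been measured and on what is new or still open speak of the compounds shown alone.

Working notes on the series. All three measured compounds share one core. Compound 1 `CCCCNC(=O)N1CC1C#N` gives 17000 nM in a functional assay on RPMI-8226 cells (Homo sapiens) for inhibition; on this read-out lower numbers stand for stronger inhibition and higher numbers for weaker inhibition. Compound 2 `CCOC(=O)c1ccc(NC(=O)N2CC2C#N)cc1` gives 3000 nM in this assay. Compound 3 `N#CC1CN1C(=O)Nc1ccc([N+](=O)[O-])cc1` gives 9100 nM in this assay; this is the second highest of the three numbers, with compound 1 within the scatter of it and compound 2 beyond the scatter. Within the data shown here, the only measured change at that aromatic position is a 3.0-fold higher number from compound 2 to compound 3 (0.48 log units; beyond the scatter).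

Compound 4 `N#CC1CN1C(=O)Nc1ccc(C(F)(F)F)cc1` is not yet measured. It differs from compound 3 by trifluoromethyl in place of nitro on an aromatic carbon. Among the measured compounds shown here, no measured step exchanges nitro for trifluoromethyl, so the direction is open; the step from compound 2 to compound 3 shows that changing the group at this position moved the number only modestly, and a change of similar size is expected here. Compound 4 is therefore expected to show a step of a 1.3-fold lower number from compound 3 to compound 4 (0.11 log units; within the scatter) relative to compound 3. Compound 4 is estimated at 7000 nM, within a range of 2500 nM to 20000 nM.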

Compound 4, half-maximal inhibitory concentration: 8200 nM
Beside the measured number, compound 4's estimate is 1.2-fold (0.07 log units) below it, within the range that was stated.
By their numbers in this assay, from the lowest: compound 2; then compounds 4, 3 and 1 (each within the scatter of the next, the first and the last beyond it).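

Exchanging nitro for trifluoromethyl on the aromatic carbon gives a 1.1-fold lower number from compound 3 to compound 4 (0.05 log units; within the scatter) in this assay, so at this position a group counted with no hydrogen-bond acceptors reads the same as one counted with two. The second replacement of ethoxycarbonyl gives a 2.7-fold higher number from compound 2 to compound 4 (0.44 log units; beyond the scatter), and with a 3.0-fold higher number from compound 2 to compound 3 (0.48 log units; beyond the scatter) there are now two replacements at this position that both end beyond the scatter on the higher side, which sets compound 2 apart from compound 3 and compound 4. Nothing available accounts for this difference or for the match between nitro and trifluoromethyl.

As far as these compounds go, whether the lower number of compound 2 depends on the ester as such stays open. A carboxylic acid, an amine or a longer ester chain at this position would test that.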